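The source may hold more compounds than are shown below. What is called first, only, known or untested is meant among the compounds shown, and "the series" means these compounds.

For the measured compounds named here, in a functional assay on HeLa cells (Homo sapiens) for cytotoxicity, read by MTT assay, with a stated time of 72 h (on this read-out lower numbers stand for stronger inhibition and higher numbers for weaker inhibition), compound 1 `O=C(/C=C/c1ccccc1[N+](=O)[O-])Nc1cc2c(Nc3ccc(F)c(Cl)c3)ncnc2cc1O[C@H]1CCOC1` gives 29600 nM and compound 2 `COc1cc(/C=C/C(=O)Nc2cc3c(Nc4ccc(F)c(Cl)c4)ncnc3cc2O[C@H]2CCOC2)cc(OC)c1O` gives 27400 nM, so compound 2 stands level with compound 1, the only other measured compound. Compound 3 `COc1ccc(/C=C/C(=O)Nc2cc3c(Nc4ccc(F)c(Cl)c4)ncnc3cc2O[C@H]2CCOC2)cc1` differs from compound 2 by 4-methoxyphenyl in place of 4-hydroxy-3,5-dimethoxyphenyl on a double-bonded chain carbon bound to a double-bonded chain carbon. Going by the values given here, the one measured step at this place, a 1.1-fold lower number from compound 1 to compound 2 (0.03 log units; within the scatter), is the only guide, so no change beyond the scatter is expected in this assay, in either direction. The expected step is a 1.1-fold lower number from compound 2 to compound 3 (0.02 log units; within the scatter). Compound 3 is estimated at 26000 nM, with a range of 12000 nM to 50000 nM.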

Compound 3, half-maximal inhibitory concentration: 34600 nM
Compound 3: the middle estimate sits 1.3-fold (0.12 log units) below what was measured; the range from low to high includes it.
By their numbers in this assay, from the lowest: compounds 2, 1 and 3 (each within the scatter of the next).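

In this assay a third aryl group at this place again leaves the number within the scatter: a 1.3-fold higher number from compound 2 to compound 3 (0.10 log units; within the scatter), and a 1.2-fold higher number from compound 1 to compound 3 (0.07 log units; within the scatter). The read-out thus does not tell 2-nitrophenyl, 4-hydroxy-3,5-dimethoxyphenyl and 4-methoxyphenyl apart here, even though compound 3 has no hydrogen-bond donor in this group and compound 2 has one. Nothing on hand offers an explanation for this flat result. As far as these compounds go, whether any group at this place can move the number beyond the scatter remains open, since all three compounds carry a substituted phenyl there. An amine or a carboxylic acid in its place could show whether this position responds at all.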